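Replacing furan-2-yl in an antiproliferative series

A few compounds are considered here, and "the series" means these few. Any claim that something is new, unique, unknown or untested is made for them only; others in the source may bear on it.

Values in a functional assay on A2780 cells (Homo sapiens) for antiproliferative activity, read by fluorescence, with a stated time of 72 h; on this read-out lower numbers stand for stronger inhibition and higher numbers for weaker inhibition:
- compound 1 `CN1CCC(C(=O)N2Cc3c(NC(=O)c4cc(F)cc(F)c4)n[nH]c3C2(C)C)CC1`: 130 nM
- compound 2 `CN1CCC(C(=O)N2Cc3c(NC(=O)c4ccsc4)n[nH]c3C2(C)C)CC1`: 140 nM
- compound 3 `CN1CCC(C(=O)N2Cc3c(NC(=O)c4ccco4)n[nH]c3C2(C)C)CC1`: > 5000 nM, a limit of the assay and not a number

Compound 3 stands at the limit of > 5000 nM in this assay, at which 1 of the 3 values shown sits, which makes it the weakest of the three. Compound 4 `CN1CCC(C(=O)N2Cc3c(NC(=O)c4ccc(C(F)(F)F)cc4)n[nH]c3C2(C)C)CC1` keeps the shared core and changes one group: 4-(trifluoromethyl)phenyl in place of furan-2-yl on a carbonyl carbon.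

Among the compounds with values here, three measured steps bear on this change. Two show a large rise on moving to furan-2-yl: an at least 38-fold higher number from compound 1 to compound 3 (1.58 log units; beyond the scatter) and an at least 35-fold higher number from compound 2 to compound 3 (1.55 log units; beyond the scatter). The third shows that two other groups on this carbonyl carbon match closely: a 1.1-fold higher number from compound 1 to compound 2 (0.03 log units; within the scatter). Furan-2-yl is therefore the only group here tied to a large loss, although this rests on just three compounds. Removing it should give a large step towards lower numbers in this assay. The expected step is an at least 16-fold lower number from compound 3 to compound 4 (1.22 log units; beyond the scatter). Within the data shown here, no measured compound carries 4-(trifluoromethyl)phenyl, so the range stays wide. For compound 4 the estimated value is 300 nM, with an expected range from 90 nM to 1500 nM.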

Compound 4, half-maximal inhibitory concentration: 60 nM
Estimate against measurement, compound 4: 5.0-fold (0.70 log units) above; the whole stated range lies above it.
By their numbers in this assay, from the lowest: compound 4; then compounds 1 and 2 (each within the scatter of the next). At a limit, above all of these: compound 3.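

Compound 3 carries a limit of the assay and not a number: the limit of > 5000 nM in this assay, at which 1 of the 4 values shown sits. Even so, in this assay the change at this carbonyl carbon gives an at least 83-fold lower number from compound 3 to compound 4 (1.92 log units; beyond the scatter), so the large loss tied to furan-2-yl does not appear with 4-(trifluoromethyl)phenyl. The new group also improves modestly on both earlier active compounds, with a 2.3-fold lower number from compound 2 to compound 4 (0.37 log units; beyond the scatter) and a 2.2-fold lower number from compound 1 to compound 4 (0.34 log units; beyond the scatter), so the level shared by compound 1 and compound 2 was not a ceiling for this position.

On these data alone, how a plain phenyl ring or a chlorophenyl group would compare with 4-(trifluoromethyl)phenyl remains open, which leaves the part played by the trifluoromethyl group itself unsettled. Also open, as far as these compounds go, is whether the loss is confined to furan-2-yl or extends to other five-membered rings, such as oxazole or thiazole.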